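Methylcarbamoyl for methylsulfanyl on the shared core: compound 3

The source may report more compounds than this note shows. Statements on the series, on what has been measured and on what is new or still open speak of the compounds shown alone.

Measured values in an assay on HEK-293T cells for inhibition of diacylglycerol lipase-alpha (Homo sapiens), read by colorimetric assay; a higher number here means a weaker inhibitor, a lower number a stronger inhibitor:
compound 1 `O=C(CCCCCCc1ccccc1)c1ncc(C(=O)C(F)(F)F)o1` gives 1820 nM.
compound 2 `CSc1cnc(C(=O)CCCCCCc2ccccc2)o1` gives a limit of the assay, > 10000 nM, and no number.

Compound 2 therefore stands at the weak end of the two values shown; its position is fixed only by the limit of > 10000 nM in this assay, at which 1 of the 2 values shown sits. Going by the values given here, the single measured step, an at least 5.4-fold higher number from compound 1 to compound 2 (0.73 log units; beyond the scatter), is at least modest and runs towards weaker inhibition when the (trifluoromethyl)carbonyl of compound 1 is exchanged for methylsulfanyl.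

Compound 3 `CNC(=O)c1cnc(C(=O)CCCCCCc2ccccc2)o1` is the next change on the same ring carbon: methylcarbamoyl in place of methylsulfanyl on an aromatic carbon. Among the compounds with values here, no measured step covers a methylcarbamoyl group, so the expectation rests on the step from compound 1 to compound 2 alone, which shows that a group other than the (trifluoromethyl)carbonyl at this position lowers inhibition in this assay by at least a modest amount. An amide is not the ketone of compound 1, so compound 3 is expected to remain weak, and a result reported only as a limit is expected to be likely. The step from compound 2 to compound 3 is expected to be an at least 1.1-fold lower number from compound 2 to compound 3 (0.04 log units; that floor lies within the scatter). For compound 3 the estimate in this assay is 9000 nM, within 2500 nM to 30000 nM.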

Compound 3, half-maximal inhibitory concentration: > 10000 nM
Compound 3 gave a limit, no number; the forecaster's own chance of this, stated with the estimate: 55%; at least 1.1-fold (0.04 log units) between middle value and limit.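

In this assay, keeping the carbonyl on this aromatic carbon and changing only what it carries, methylamino in place of trifluoromethyl, gives an at least 5.4-fold higher number from compound 1 to compound 3 (0.73 log units; beyond the scatter), a step of at least modest size. A carbonyl at this position therefore does not by itself preserve the measurable inhibition of compound 1, a point that compound 2 could not show, as it lacks a carbonyl on this ring carbon altogether. The step from compound 2 to compound 3 cannot be read, because both compounds stand at the same limit and neither has a number: the limit of > 10000 nM in this assay, at which 2 of the 3 values shown sit.

Going by these compounds alone, compound 1 remains the only compound here with a number, so methylsulfanyl and methylcarbamoyl cannot be ranked against each other, and how far either lies beyond the limit remains open. Also open, on these data alone, is whether a different group on this ring carbon, such as a methyl ketone, a nitrile or a carboxylic acid, would return a number in this assay, and whether a longer chain would change the picture for the trifluoromethyl ketone of compound 1.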